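A few compounds are considered here, and "the series" means these few. Any claim that something is new, unique, unknown or untested is made for them only; others in the source may bear on it.

Working notes on the coumarin-chalcone series, on the step from compound 1 to compound 4.

Compound 1 `COc1ccc(/C=C/C(=O)c2cc3ccc(OCc4cccc(OC)c4)cc3oc2=O)cc1` carries a benzyloxy ether on the shared core and a methoxy group on the styryl phenyl ring. In a functional assay on MCF7 cells (Homo sapiens) for cytotoxicity, read by MTT assay, with a stated time of 72 h (a higher number here means a weaker inhibitor, a lower number a stronger inhibitor), compound 1 gives only a limit, > 100000 nM, and not a number. Two related compounds with a free hydroxyl on the core in place of the ether do return numbers: compound 2 `COc1cc(/C=C/C(=O)c2cc3cc(O)ccc3oc2=O)cc(OC)c1OC` gives 10900 nM in this assay, and compound 3 `COc1cccc(/C=C/C(=O)c2cc3ccc(O)cc3oc2=O)c1OC` gives 16600 nM. Compound 1 thus sits at the weak end of what has been measured, at the limit of > 100000 nM in this assay, at which 1 of the 3 values shown sits.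

Compound 4 `COc1cccc(COc2ccc3cc(C(=O)/C=C/c4ccc(C)cc4)c(=O)oc3c2)c1` keeps the benzyloxy ether of compound 1 and differs from it only on the styryl phenyl ring: methyl in place of methoxy on an aromatic carbon. Among the measured compounds shown here, no measured pair isolates this change, so no step size can be read from the data. With the ether retained, the expectation is that compound 4 stays where compound 1 stands, and the step from a step that the limit leaves unreadable from compound 1 to compound 4 is estimated as none beyond the scatter. Compound 4 is therefore expected to give about 150000 nM in this assay, within a range of 40000 nM to 600000 nM, and most likely to be reported again only as a limit.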

Compound 4, half-maximal inhibitory concentration: > 50000 nM
Compound 4: only a limit was reported; the forecaster's own chance of this, stated with the estimate: 75%; the middle value is on the limit's open side.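

Among the compounds shown here, compound 1 and compound 4 each return only a limit in this assay, so no step between them can be read. The compounds shown leave open whether methyl in place of methoxy on the styryl phenyl ring moves the value at all while the benzyloxy ether stays on the shared core.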